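Fluoro in place of hydrogen on the fused ring

The source may report more compounds than this note shows. Statements on the series, on what has been measured and on what is new or still open speak of the compounds shown alone.

Measured so far:
compound 1 `CC(C)(O)c1cncc(-n2ncc3ccccc32)c1` gives 535 nM
compound 2 `Cc1nn(-c2cncc(C(C)(C)O)c2)c2ccccc12` gives 779 nM

These two compounds were tested in an ADME assay on cells for inhibition of cytochrome P450 11B1, mitochondrial (Homo sapiens), read by HTRF, with stated times of 1 h and 3 h; on this read-out higher numbers stand for weaker inhibition and lower numbers for stronger inhibition. Compound 1 and compound 2 share one core and differ only by a methyl group on an aromatic carbon; the step of a 1.5-fold higher number from compound 1 to compound 2 (0.16 log units; within the scatter) shows that this small addition left the number essentially unchanged, so neither compound can be called stronger or weaker than the other.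

The next compound, compound 3 `CC(C)(O)c1cncc(-n2ncc3cccc(F)c32)c1`, has not yet been measured. It differs from compound 1 in this way: fluoro in place of hydrogen on an aromatic carbon. For the measured compounds named here, the only measured step that bears on such a small change on the same core is the one from compound 1 to compound 2, and it stayed within the scatter. A step of similar size is therefore expected here, with no direction beyond the scatter, so that compound 3 is estimated to give 500 nM in this assay, between 250 nM and 1000 nM; this is the expected step of a 1.1-fold lower number from compound 1 to compound 3 (0.03 log units; within the scatter).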

Compound 3, half-maximal inhibitory concentration: 10.7 nM
Estimate against measurement, compound 3: 47-fold (1.67 log units) above; the measured number lies below the stated range.
By their numbers in this assay, from the lowest: compound 3; then compounds 1 and 2 (each within the scatter of the next).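

A single fluoro group swapped for a ring hydrogen of the fused ring system gives a 50-fold lower number from compound 1 to compound 3 (1.70 log units; beyond the scatter) in this assay, which means much stronger inhibition, so this one small replacement can matter a great deal on the shared core. The earlier methyl change gave only a 1.5-fold higher number from compound 1 to compound 2 (0.16 log units; within the scatter), so not every small addition to this core shifts the number, although that step differs from this one in both the group and its place. Nothing available here explains why the number falls so far.

Going by these compounds, it remains open whether this drop belongs to fluoro itself or would also appear with chloro, methoxy or a nitrile on the same carbon. On these data alone, it is also open whether fluoro on the other carbons of that ring would give a step of similar size.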